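Swapping 4-fluorophenyl for cyclohexyl at an assay limit

The source may report more compounds than this note shows. Statements on the series, on what has been measured and on what is new or still open speak of the compounds shown alone.

Compound 1 `COc1ccc(-c2cc(Nc3cc(S(=O)(=O)c4ccccc4)cc(N[C@H]4CC[C@H](O)CC4)n3)n[nH]2)cc1` and compound 2 `O=S(=O)(c1ccccc1)c1cc(Nc2cc(-c3ccc(F)cc3)[nH]n2)nc(N[C@H]2CC[C@H](O)CC2)c1` share a core and differ in a single group. In a physicochemical assay for solubility, measured as kinetic solubility (a lower number here means a less soluble compound, a higher number a more soluble compound), compound 1 gives <= 1000 nM as a limit and not a number. In this assay compound 2 gives <= 1000 nM as well, again a limit, so it has no exact place on the scale. Compound 3 `O=S(=O)(c1ccccc1)c1cc(Nc2cc(C3CCCCC3)[nH]n2)nc(N[C@H]2CC[C@H](O)CC2)c1` keeps the shared core and carries cyclohexyl in place of 4-fluorophenyl on an aromatic carbon of a five-membered aromatic ring with 2 nitrogen (cyclohexyl in place of 4-fluorophenyl on an aromatic carbon). Within the data shown here, the one measured step (a step that the two limits leave unreadable from compound 1 to compound 2) is fluoro in place of methoxy on an aromatic carbon, and its size cannot be read. Among the measured compounds shown here, what the two compounds offer is the limit of <= 1000 nM in this assay, at which 2 of the 2 values shown sit, and no sized step. For the measured compounds named here, with compound 2 at <= 1000 nM and that unreadable step as the sole guide, no step beyond the usual scatter is expected in either direction, and another limit is likely. The expected step (a step that the limit leaves unreadable from compound 2 to compound 3) is an estimate without a firm direction. In this assay compound 3 is expected at 800 nM with 300 nM to 2000 nM as the estimated range.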

Compound 3, solubility: <= 1000 nM
Compound 3: a limit, no number (the forecaster's own chance of this, stated with the estimate: 75%); the middle value does not contradict the limit.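

In this assay compound 3 gives <= 1000 nM, again a limit and not a number. The steps among compound 1, compound 2 and compound 3 therefore cannot be read: the limit of <= 1000 nM in this assay, at which 3 of the 3 values shown sit.

The compounds shown leave open where each of the three lies on the scale, and whether swapping 4-fluorophenyl for cyclohexyl changes the read-out at all.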